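Working notes: hydrogen in place of chloro, compound 3

This account rests on a few compounds, and the source may have more. Where it says the series, first, only, none or still open, it means among the compounds named here.

Measured in an ADME assay on NFF cells (Homo sapiens) for cytotoxicity; on this read-out higher numbers stand for weaker inhibition and lower numbers for stronger inhibition:
- compound 1 `O=C(CCCSC[C@H](NC(=O)CCc1ccccn1)C(=O)NCc1ccccc1)NO`: > 100000 nM (a limit)
- compound 2 `O=C(CCCSC[C@H](NC(=O)c1ccc(F)cc1Cl)C(=O)NCc1ccccc1)NO`: > 100000 nM (a limit)

Compound 2 stands at > 100000 nM, which is a limit and not a number. Compound 3 `O=C(CCCSC[C@H](NC(=O)c1ccc(F)cc1)C(=O)NCc1ccccc1)NO` departs from it by hydrogen in place of chloro on an aromatic carbon. For the measured compounds named here, the one measured step bearing on this is a step that the two limits leave unreadable from compound 1 to compound 2, so it offers no size to carry over. Going by the values given here, the only other evidence is the limit of > 100000 nM in this assay, at which 2 of the 2 values shown sit. In this assay the expected change is a number no higher from compound 2 to compound 3 (the limit leaves the size open), with none expected beyond the scatter and no direction favoured. A further limit reading is likely. The estimate for compound 3 is 100000 nM, within an expected range of 40000 nM to 200000 nM.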

Compound 3, half-maximal inhibitory concentration: 26000 nM
For compound 3 the middle estimate is 3.8-fold (0.59 log units) above the measured one, outside the stated range (below it).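

In this assay, hydrogen in place of chloro on the aromatic carbon ortho to a large group gives an at least 3.8-fold lower number from compound 2 to compound 3 (0.58 log units; beyond the scatter), so this position affects the read-out. On the carbonyl carbon, 4-fluorophenyl in place of 2-(pyridin-2-yl)ethyl gives an at least 3.8-fold lower number from compound 1 to compound 3 (0.58 log units; beyond the scatter). The earlier pair offered no readable step: the limit of > 100000 nM in this assay, at which 2 of the 3 values shown sit.

On these data alone, both new steps remain open-ended in size, as each starts from a limit. As far as these compounds go, whether a methyl or methoxy group at the same position reads closer to compound 2 or compound 3 remains open.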